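The compounds below may be only part of what the source reports. "The series", "measured", "known", "first", "only" and "open" are said of these compounds alone.

Measured in an ADME assay on CEM-SS cells (Homo sapiens) for cytotoxicity, read by XTT assay, with a stated time of 6 days; a lower number here means that less compound is tolerated, a higher number that more compound is tolerated:
- compound 1 `CCCC(=O)OCSc1ccccc1C(=O)NCC(=O)NC(C)C`: 92 uM
- compound 2 `CCCC(=O)OCSc1ccccc1C(=O)NCC(=O)NC(C)(C)C`: 46.8 uM

Compound 2, at 46.8 uM, cannot be told apart from compound 1 in this assay. Compound 3 `CCCC(=O)OCSc1ccccc1C(=O)NCC(=O)NCC(=O)OC` has (methoxycarbonyl)methyl in place of tert-butyl on an amide-type nitrogen. Going by the values given here, the only measured step, a 2.0-fold lower number from compound 1 to compound 2 (0.29 log units; within the scatter), also concerns the group on that nitrogen and is small. Neither compound 1 nor compound 2 carries a (methoxycarbonyl)methyl, so the data offer no firm direction, and no change beyond the scatter is expected. The expected change is a 1.3-fold higher number from compound 2 to compound 3 (0.11 log units; within the scatter). For compound 3 the estimated value is 60 uM, with a range of 25 uM to 150 uM.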

Compound 3, half-maximal toxic concentration: > 100 uM
Compound 3 ended at the assay's limit; the forecaster's own chance of this, stated with the estimate: 20%; middle value at least 1.6-fold (0.22 log units) away from the limit.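

In this assay, compound 3 gives > 100 uM, which is a limit of the assay and not a number. Going by these compounds alone, the change of group on the amide-type nitrogen gives an at least 2.1-fold higher number from compound 2 to compound 3 (0.32 log units; beyond the scatter), so this position can shift the tolerated concentration beyond the scatter, which the only earlier step did not show. Against isopropyl, the same group gives an at least 1.0-fold higher number from compound 1 to compound 3 (0.03 log units; that floor lies within the scatter), so that floor does not separate the two compounds, and the reading is bounded: the limit of > 100 uM in this assay, at which 1 of the 3 values shown sits.

On these data alone, how far compound 3 lies past the limit stays unknown. Also open, as far as these compounds go, is whether a carboxylic acid or a longer chain on this nitrogen would give a similar reading.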